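This account rests on a few compounds, and the source may have more. Where it says the series, first, only, none or still open, it means among the compounds named here.

Measured so far in a functional assay on HEK293 cells (Homo sapiens) for inhibition; a higher number here means a weaker inhibitor, a lower number a stronger inhibitor:
compound 1 `CCCCCCCCCCCCCCCCS(=O)(=O)NCCCOCCCCOCCCN` gives 22400 nM
compound 2 `CCCCCCCCCCCCCCCCS(=O)(=O)NCCCCCCCCCCCCN` gives 200000 nM

Compound 2, at 200000 nM, holds the higher of the two numbers and is the weaker inhibitor, beyond the scatter. Compound 3 `CCCCCCCCCCCCCCCCS(=O)(=O)NCCN(CCN)CCN` differs from it as follows: bis(2-aminoethyl)amino in place of 10-aminodecyl on a saturated chain carbon, two bonds along the chain from a sulfonamide nitrogen. Going by the values given here, only one measured step bears on this change, the modest 8.9-fold higher number from compound 1 to compound 2 (0.95 log units; beyond the scatter), which ended on the chain of compound 2. Compound 3 gives up that chain, so a step of similar size towards a lower number is expected in this assay, on thin evidence. The expected step is a 10-fold lower number from compound 2 to compound 3 (1.00 log units; beyond the scatter), as estimated. For compound 3 the estimated value is 20000 nM, with an expected range of 4000 nM to 100000 nM.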

Compound 3, half-maximal inhibitory concentration: 379 nM
For compound 3 the middle estimate is 53-fold (1.72 log units) above the measured one; the measured number lies below the stated range.
By their numbers in this assay, from the lowest: compound 3; then compound 1; then compound 2.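

In this assay, going by these compounds alone, bis(2-aminoethyl)amino in place of 10-aminodecyl gives a 530-fold lower number from compound 2 to compound 3 (2.72 log units; beyond the scatter), a step well beyond any seen between the earlier compounds. The bis(2-aminoethyl)amino group also outdoes the larger chain of compound 1, with a 59-fold lower number from compound 1 to compound 3 (1.77 log units; beyond the scatter), so at this position a smaller group carrying more nitrogen goes with the lower number. Nothing measured here accounts for this gain. Going by these compounds, whether it needs both aminoethyl arms remains open. A single 2-aminoethyl group or longer 3-aminopropyl arms would separate the effects of branching, arm length and nitrogen count.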